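This account rests on a few compounds, and the source may have more. Where it says the series, first, only, none or still open, it means among the compounds named here.

Measured in a functional assay on B16-F10 cells (Mus musculus) for antiproliferative activity, read by CCK-8 assay, with a stated time of 48 h; a lower number here means a stronger inhibitor, a higher number a weaker inhibitor:
Compound 1 `COc1ccc(/C=C\c2cc(OC)c(OC)c(OC)c2)cc1OCc1ccc(C=O)cc1`: 4200 nM
Compound 2 `COc1ccc(/C=C\c2cc(OC)c(OC)c(OC)c2)cc1OCc1ccc(CN2CCCC[C@H]2C(=O)O)cc1`: > 10000 nM (a limit, not a number)
Compound 3 `COc1ccc(/C=C\c2cc(OC)c(OC)c(OC)c2)cc1OCc1ccc(CN2CCCCC2C(=O)NCCNC(=O)OC(C)(C)C)cc1`: 4700 nM

Compound 2 sits at the limit of > 10000 nM in this assay, at which 1 of the 3 values shown sits.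

Compound 4 `COc1ccc(/C=C\c2cc(OC)c(OC)c(OC)c2)cc1OCc1ccc(CN2CC[C@H](C(=O)O)C2)cc1`, not yet measured, carries 3-carboxypyrrolidin-1-yl in place of 2-carboxypiperidin-1-yl on a saturated chain carbon bound to an aromatic carbon.

For the measured compounds named here, one measured step bears on this change, an at least 2.3-fold higher number from compound 1 to compound 2 (0.37 log units; beyond the scatter), and it is at least modest. It replaced formyl with (2-carboxypiperidin-1-yl)methyl. Going by the values given here, no measured step covers the change of ring itself, and compound 4 keeps the carboxyl group, so no clear shift in this assay is expected in either direction.

The expected step is a step that the limit leaves unreadable from compound 2 to compound 4.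

Compound 4 is estimated at 12000 nM, with an expected range of 5000 nM to 30000 nM.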

Compound 4, half-maximal inhibitory concentration: 7000 nM
For compound 4 the middle estimate is 1.7-fold (0.23 log units) above the measured one, within the range that was stated.
By their numbers in this assay, from the lowest: compounds 1, 3 and 4 (each within the scatter of the next). At a limit, above all of these: compound 2.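

In this assay compound 2 remains a limit and not a number: the limit of > 10000 nM in this assay, at which 1 of the 4 values shown sits. The change to 3-carboxypyrrolidin-1-yl gives an at least 1.4-fold lower number from compound 2 to compound 4 (0.15 log units; that floor lies within the scatter) and so establishes no real gain. New at this position is that (3-carboxypyrrolidin-1-yl)methyl in place of formyl gives a 1.7-fold higher number from compound 1 to compound 4 (0.22 log units; within the scatter) and thus a carboxyl-bearing ring with a measured value level with compound 1.

On these data alone, whether ring size or the place of the carboxyl group decides the outcome stays open, and 3-carboxypiperidin-1-yl would bear on that. As far as these compounds go, whether a methyl ester would behave like the carboxylic acid also stays open.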